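Para-substituent change on the shared core: chloro to hydroxy

The source may hold more compounds than are shown below. What is called first, only, known or untested is meant among the compounds shown, and "the series" means these compounds.

Measured compounds in an assay on cells for displacement of a labelled ligand from adenosine receptor A1 (Homo sapiens), read by scintillation counting and radioligand binding, with a stated time of 60 min; on this read-out higher numbers stand for weaker inhibition and lower numbers for stronger inhibition:
- compound 1 `CN1CCN(c2nc(-c3ccc(Cl)cc3)nc3[nH]cnc23)CC1`: 398 nM
- compound 2 `CN1CCN(c2nc(-c3ccc(Cl)c(Cl)c3)nc3[nH]cnc23)CC1`: 631 nM
- compound 3 `CN1CCN(c2nc(-c3cccc(Cl)c3)nc3[nH]cnc23)CC1`: 79.4 nM

Compound 1 stands second highest of the three numbers. Among the measured compounds shown here, its nearest neighbour is compound 2, reached by a 1.6-fold higher number from compound 1 to compound 2 (0.20 log units; within the scatter); the step of a 5.0-fold lower number from compound 1 to compound 3 (0.70 log units; beyond the scatter) is the furthest and is the only one from compound 1 that clears the scatter. The step of a 7.9-fold lower number from compound 2 to compound 3 (0.90 log units; beyond the scatter) removes the same chloro that a 1.6-fold higher number from compound 1 to compound 2 (0.20 log units; within the scatter) adds, while also shifting the remaining chloro, so the two chloro-bearing compounds and the single swing of the chloro position make up all that is known of the series.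

Compound 4 `CN1CCN(c2nc(-c3ccc(O)cc3)nc3[nH]cnc23)CC1` is not yet measured. It differs from compound 1 by hydroxy in place of chloro on an aromatic carbon. For the measured compounds named here, no measured step touches this exchange: the steps above either add or remove a second chloro, or move a chloro, and none brings a hydroxy onto the ring. Going by the values given here, the only guidance is that the para-position chloro of compound 1 sits on the weaker side of the series, so a change there could run either way. Among the compounds with values here, with no directly comparable step, a modest weakening with wide uncertainty is the working expectation: the step from compound 1 to compound 4 is expected to be a 2.0-fold higher number from compound 1 to compound 4 (0.30 log units; within the scatter), and compound 4 is estimated at 800 nM, within 200 nM to 3200 nM.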

Compound 4, inhibition constant: 398 nM
Compound 4: middle estimate off by 2.0-fold (0.30 log units), on the high side; measured number inside the range.
By their numbers in this assay, from the lowest: compound 3; then compounds 1, 4 and 2 (each within the scatter of the next).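

In this assay, the 4-chlorophenyl to 4-hydroxyphenyl exchange gives no change at the digits printed from compound 1 to compound 4 (within the scatter) and so shows that, at this place para to a large group, two groups that differ in their atom and in their hydrogen-bond donor and acceptor counts read alike. Compound 4 also lies within the scatter of the 3,4-dichlorophenyl compound, with a 1.6-fold lower number from compound 2 to compound 4 (0.20 log units; within the scatter) on record, while a 5.0-fold higher number from compound 3 to compound 4 (0.70 log units; beyond the scatter) clears the scatter, which leaves the 3-chlorophenyl of compound 3 alone at the low-number end of the four compounds. No other measurement bears on this result, so why chloro and hydroxy read alike here stays unknown.

From the compounds shown here alone, whether this level reading extends to other groups at the same place, such as an amine, a methoxy or a carboxylic acid, stays open. Also open, going by these compounds, is whether hydroxy in place of chloro would read the same on the 3-chlorophenyl of compound 3, which has the lowest number and may not tolerate the exchange as compound 1 does.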